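This account rests on a few compounds, and the source may have more. Where it says the series, first, only, none or still open, it means among the compounds named here.

Measured compounds in a functional assay on PC-3 cells (Homo sapiens) for cytotoxicity, read by MTT assay, with a stated time of 48 h, tested at 25 uM; on this read-out higher numbers stand for a stronger effect at the one concentration tested and lower numbers for a weaker effect:
compound 1 `O=C(c1ccc(O)cc1O)[C@H]1[C@H](c2ccccc2)[C@H](C(=O)c2ccc(O)cc2O)[C@H]1c1ccccc1` gives 88%
compound 2 `O=C(c1ccc(O)cc1O)[C@H]1[C@H](c2ccccc2)[C@H](C(=O)c2ccc(O)cc2O)[C@@H]1c1ccccc1` gives 57.9%
compound 3 `O=C(c1ccc(O)cc1O)[C@@H]1[C@H](C(=O)c2ccc(O)cc2O)[C@@H](c2ccccc2)[C@H]1c1ccccc1` gives 78.8%

Compound 3 stands second highest of the three numbers. Its nearest neighbour is compound 1, and that gap is within the scatter, so no order between compound 3 and compound 1 is claimed. Its furthest neighbour is compound 2, whose gap to compound 3 lies beyond the scatter, so compound 3 gives the larger read-out of that pair.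

Compound 4 `O=C(c1ccc(O)cc1O)[C@@H]1[C@@H](C(=O)c2ccc(O)cc2O)[C@H](c2ccccc2)[C@@H]1c1ccccc1` is not yet measured. It differs from compound 3 as follows: the two compounds have the same atoms and bonds and differ only in configuration as drawn: 1 of 4 stereo elements differ; a stereocentre at a saturated ring carbon is drawn R in compound 3 and S in compound 4.

Going by the values given here, one measured step bears on this change: the step of a number 30.1 percentage points lower from compound 1 to compound 2 (beyond the scatter), which rests on (the fact that compounds 1 and 2 differ only in the configuration as drawn). There a change in configuration alone moved the read-out by a large amount. The step to compound 4 changes one stereo element where that step changed two, so a shift of comparable or smaller size is plausible, but its direction cannot be fixed from three compounds. The expectation for compound 4 is therefore broad and centred somewhat below compound 3. The expected step is a number 10.8 percentage points lower from compound 3 to compound 4 (beyond the scatter). Compound 4 is estimated at 68%, within 45% to 90%.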

Compound 4, a percentage reported as activity, at one concentration (the size of the read-out at that concentration, not a potency): 75.5%
For compound 4 the middle estimate is 7.5 percentage points below the measured one; the measured number falls inside the stated range.
By their numbers in this assay, from the lowest: compound 2; then compounds 4, 3 and 1 (each within the scatter of the next, the first and the last beyond it).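

In this assay, a single stereocentre at a saturated ring carbon, drawn R in compound 3 and S in compound 4, gives a number 3.3 percentage points lower from compound 3 to compound 4 (within the scatter). Going by these compounds alone, this is the first pair that differs in only one stereo element, and its two numbers cannot be told apart, so a difference in configuration as drawn does not by itself guarantee a separable read-out. The contrast is with the pair differing in two stereo elements, which gave a number 30.1 percentage points lower from compound 1 to compound 2 (beyond the scatter) and remains the only listed step beyond the scatter, while the new step isolates a single centre, with nothing else separating its two compounds: the fact that compounds 3 and 4 differ only in the configuration as drawn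

Still open, from the compounds shown here alone, is which of the two stereo elements separating compound 1 from compound 2 carries that large step, or whether it takes both together, and whether the centre changed here would behave alike in another stereo setting. All four compounds share the same atoms and bonds, so these numbers say nothing about how an amine or a carboxylic acid on the shared core, or a longer chain in place of a phenyl group, would read out in this assay.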